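Chloro for hydrogen on the aryl ring of compound 3

The source may hold more compounds than are shown below. What is called first, only, known or untested is meant among the compounds shown, and "the series" means these compounds.

Measured compounds:
Compound 1, `COc1cccc(-c2n[nH]cc2N2CCNCC2)c1`: > 10000 nM in an assay on isolated protein for binding affinity to 5-hydroxytryptamine receptor 4 (Homo sapiens) (on this read-out lower numbers stand for stronger inhibition and higher numbers for weaker inhibition), a limit of the assay and not a number.
Compound 2, `COc1ccc(-c2n[nH]cc2N2CCNCC2)cc1`: > 10000 nM in this assay, again a limit.
Compound 3, `c1ccc(-c2n[nH]cc2N2CCNCC2)cc1`: > 10000 nM in this assay, again a limit.

All three values sit at the same limit (the limit of > 10000 nM in this assay, at which 3 of the 3 values shown sit), so compound 3 cannot be placed above or below compounds 1 and 2; its standing on the numbers shown is simply at that limit. The two steps towards it, a step that the two limits leave unreadable from compound 1 to compound 3 and a step that the two limits leave unreadable from compound 2 to compound 3, each exchange methoxy for hydrogen on an aromatic carbon, yet their size stays hidden behind the limits.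

Compound 4, `Clc1cccc(-c2n[nH]cc2N2CCNCC2)c1`, arises from compound 3 by chloro in place of hydrogen on an aromatic carbon, the chloro sitting on an aromatic carbon of a six-membered aromatic ring of carbon only, meta to a large group. Among the measured compounds shown here, no measured step gives a readable size for a change at such a position, and the two unreadable steps offer no direction. The expectation is therefore that the step of a number no higher from compound 3 to compound 4 (the limit leaves the size open) stays within the scatter. Compound 4 is accordingly estimated at 10000 nM, in a range from 2500 nM to 40000 nM, most likely reported again as a limit.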

Compound 4, inhibition constant: > 10000 nM
Compound 4 was reported as a limit; the forecaster's own chance of this, stated with the estimate: 75%; the middle value lies on the limit itself.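

Compound 4 is again reported as a limit of the assay, so no size can be read for its steps from compound 3 or compound 1, because every value shown rests at the same limit: the limit of > 10000 nM in this assay, at which 4 of the 4 values shown sit. The compounds shown leave open whether any change on the aryl ring gives a readable value in this assay at all.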